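The source may hold more compounds than are shown below. What is called first, only, known or untested is meant among the compounds shown, and "the series" means these compounds.

Three compounds have been measured in a functional assay on HepG2 cells (Homo sapiens) for inhibition, with a stated time of 72 h; on this read-out higher numbers stand for weaker inhibition and lower numbers for stronger inhibition:

Compound 1, `O=C(Nc1ccc(Cl)cc1)Nc1nc(Sc2c[nH]c3ccccc23)cc(N2CCCC2)n1`, gives 7870 nM.
Compound 2, `COc1ccc(NC(=O)Nc2nc(Nc3cc(OC)cc(OC)c3)cc(Sc3c[nH]c4ccccc34)n2)cc1`, gives 17400 nM.
Compound 3, `COc1ccc(NC(=O)Nc2nc(Sc3c[nH]c4ccccc34)cc(N3CCCC3)n2)cc1`, gives 20300 nM.

Compound 3 has the highest number of the three in this assay. Its gap to compound 2 is within the scatter, so these two cannot be told apart, as a 1.2-fold higher number from compound 2 to compound 3 (0.07 log units; within the scatter) shows. Its gap to compound 1 is beyond the scatter, as a 2.6-fold higher number from compound 1 to compound 3 (0.41 log units; beyond the scatter) shows. Compound 4, `Cc1cc(Cl)ccc1NC(=O)Nc1nc(Sc2c[nH]c3ccccc23)cc(N2CCCC2)n1`, has not been measured. It differs from compound 3 in one place: 4-chloro-2-methylphenyl in place of 4-methoxyphenyl on an amide-type nitrogen. Of the two measured steps, a 1.2-fold higher number from compound 2 to compound 3 (0.07 log units; within the scatter) concerns another part of the shared core and says nothing about this change. The other, a 2.6-fold higher number from compound 1 to compound 3 (0.41 log units; beyond the scatter), concerns the same site and runs the opposite way: chloro was exchanged for methoxy and the number rose. Compound 4 brings the chloro back and adds a methyl, for which no measurement exists. Because compound 1 gives 7870 nM, a modest fall in the number is expected, a 5.8-fold lower number from compound 3 to compound 4 (0.76 log units; beyond the scatter). Compound 4 is estimated at 3500 nM, with a range from 1400 nM to 9000 nM.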

Compound 4, half-maximal inhibitory concentration: 7150 nM
Beside the measured number, compound 4's estimate is 2.0-fold (0.31 log units) below it, within the range that was stated.
By their numbers in this assay, from the lowest: compounds 4 and 1 (each within the scatter of the next); then compounds 2 and 3 (each within the scatter of the next).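

In this assay, exchanging 4-methoxyphenyl for 4-chloro-2-methylphenyl on the amide-type nitrogen gives a 2.8-fold lower number from compound 3 to compound 4 (0.45 log units; beyond the scatter), a second change at this site that moves the number beyond the scatter. The added methyl is a different matter: it gives only a 1.1-fold lower number from compound 1 to compound 4 (0.04 log units; within the scatter), so compound 1 and compound 4 cannot be told apart, and the drop from compound 3 is matched by the chloro-for-methoxy step alone, with nothing further seen from the methyl. Nothing measured here gives a reason for either step.

As far as these compounds go, it remains open whether a group such as bromo, trifluoromethyl or a dimethylamino group in place of the chloro would lower the number further. From the compounds shown here alone, it is also open whether 4-chloro-2-methylphenyl would behave the same with (3,5-dimethoxyphenyl)amino in place of pyrrolidin-1-yl on the shared core.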